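Epimer step from compound 2 to compound 3

The source may report more compounds than this note shows. Statements on the series, on what has been measured and on what is new or still open speak of the compounds shown alone.

Measured so far:
compound 1 `C=C1C[C@@H]2OC(=O)C3=CCC[C@H]4[C@]15C[C@H](c1ccoc1)O[C@H]5OC(=O)[C@]324`: 7450 nM
compound 2 `C=C1CC[C@]23C(C(=O)OC)=CCC[C@H]2[C@]12C[C@H](c1ccoc1)O[C@H]2O[C@@H]3O`: >= 10000 nM

In a functional assay on P388 cells (Mus musculus) for cytotoxicity, read by MTT assay, with a stated time of 72 h (on this read-out higher numbers stand for weaker inhibition and lower numbers for stronger inhibition), compound 1 gives 7450 nM. For compound 2 the read-out is a limit and not a number, >= 10000 nM. Going by these compounds, compound 2 therefore stands at the limit of >= 10000 nM in this assay, at which 1 of the 2 values shown sits, so its true value is unknown beyond that edge.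

Compound 3 `C=C1CC[C@]23C(C(=O)OC)=CCC[C@H]2[C@]12C[C@H](c1ccoc1)O[C@H]2O[C@H]3O` is the next point. Compared with compound 2, (the two compounds have the same atoms and bonds and differ only in configuration as drawn: 1 of 6 stereo elements differ; a stereocentre at a saturated ring carbon is drawn S in compound 2 and R in compound 3). Within the data shown here, no measured step of this kind exists, and the change touches configuration only, so no shift beyond the usual scatter is expected in this assay in either direction.

Compound 3 is expected to give 12000 nM, with a range from 5000 nM to 30000 nM. The estimated step that the limit leaves unreadable from compound 2 to compound 3 is expected to lie within the scatter, and the measurement is expected most likely to return a limit again rather than a number.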

Compound 3, half-maximal inhibitory concentration: >= 10000 nM
Compound 3: a limit, no number; the forecaster's own chance of this, stated with the estimate: 65%; the middle value does not contradict the limit.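

Compound 2 and compound 3 both return a limit and not a number in this assay, so no step can be read between them. Still open, going by these compounds, is whether the S or R configuration at this saturated ring carbon changes the read-out, and how far past the limit either true value lies.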